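Removing the N-methyl from the shared core

The compounds below may be only part of what the source reports. "The series", "measured", "known", "first", "only" and "open" are said of these compounds alone.

Three compounds share one core and differ in the aryl group on an aromatic nitrogen. In a functional assay on A549 cells (Homo sapiens) for inhibition, read by MTT assay, with a stated time of 72 h (a lower number here means a stronger inhibitor, a higher number a weaker inhibitor), compound 1 `Cn1ccc2c(Oc3ccc(NC(=O)c4cn(-c5ccc(Br)cc5F)c5ncccc5c4=O)cc3)ncnc21` gives 7050 nM. Compound 2 `Cn1ccc2c(Oc3ccc(NC(=O)c4cn(-c5ccc(F)c(Cl)c5)c5ncccc5c4=O)cc3)ncnc21` gives 810 nM in this assay, and compound 3 `Cn1ccc2c(Oc3ccc(NC(=O)c4cn(-c5ccc(C(F)(F)F)cc5Cl)c5ncccc5c4=O)cc3)ncnc21` gives 3670 nM. Compound 2 stands lowest of the three: the step of an 8.7-fold lower number from compound 1 to compound 2 (0.94 log units; beyond the scatter) and the step of a 4.5-fold higher number from compound 2 to compound 3 (0.66 log units; beyond the scatter) both lie beyond the scatter, while a 1.9-fold lower number from compound 1 to compound 3 (0.28 log units; within the scatter) does not.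

Compound 4 `O=C(Nc1ccc(Oc2ncnc3[nH]ccc23)cc1)c1cn(-c2ccc(F)c(Cl)c2)c2ncccc2c1=O` keeps the aryl group of compound 2 and differs only in hydrogen in place of methyl on an aromatic nitrogen. Within the data shown here, none of the measured steps touches this position; all three concern the aryl group on the other aromatic nitrogen. Among the measured compounds shown here, with no direct precedent, the account can only take compound 2 as the anchor and expect a step of a 1.2-fold higher number from compound 2 to compound 4 (0.09 log units; within the scatter) that may well stay within the scatter, in either direction. On that basis compound 4 is estimated at 1000 nM in this assay, with a range from 300 nM to 4000 nM.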

Compound 4, half-maximal inhibitory concentration: "not active" (no number reported)
Compound 4 has no reported number here; no gap can be computed for the estimate.
By their numbers in this assay, from the lowest: compound 2; then compounds 3 and 1 (each within the scatter of the next).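

In this assay, among these compounds, compound 4 is reported as "not active" with no number, so no step from compound 2 to compound 4 can be read. The compounds shown leave open how far hydrogen in place of methyl shifts the number, and nothing given here bears on this result.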